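A few compounds are considered here, and "the series" means these few. Any claim that something is new, unique, unknown or untested is made for them only; others in the source may bear on it.

Measured in a functional assay on U-937/GTB cells (Homo sapiens) for cytotoxicity; on this read-out lower numbers stand for stronger inhibition and higher numbers for weaker inhibition:
- compound 1 `CO/N=c1\[nH]cnc2c1[n+](C/C=C(\C)CC/C=C(\C)CC/C=C(\C)CCC=C(C)C)cn2CCC#N`: 3330 nM
- compound 2 `CO/N=c1\[nH]cnc2c1[n+](C/C=C(\C)CC/C=C(\C)CC/C=C(\C)CCC=C(C)C)cn2Cc1ccccc1`: 1070 nM
- compound 3 `CO/N=c1\[nH]cnc2c1[n+](C/C=C(\C)CC/C=C(\C)CC/C=C(\C)CCC=C(C)C)cn2C(c1ccccc1)c1ccccc1`: 1970 nM

In this small set, compound 3 at 1970 nM lies within the usual scatter of both other compounds, although those two do separate, with a 3.1-fold lower number from compound 1 to compound 2 (0.49 log units; beyond the scatter). The next compound, compound 4 `CC(C)=CCC/C(C)=C/CC/C(C)=C/CC/C(C)=C/C[n+]1cn(C(c2ccccc2)c2ccccc2)c2nc[nH]/c(=N\OCc3ccccc3)c21`, keeps everything in compound 3 except one feature. The change is phenyl in place of hydrogen on a saturated chain carbon bound to an oxygen, or methoxy to benzyloxy.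

Among the compounds with values here, no measured step touches this place, so the evidence is only indirect. The closest parallel is the same exchange of hydrogen for phenyl on a saturated chain carbon bound to an aromatic carbon and an aromatic nitrogen, which gave a 1.8-fold higher number from compound 2 to compound 3 (0.27 log units; within the scatter). The other step replaced cyanomethyl with phenyl and gave a 3.1-fold lower number from compound 1 to compound 2 (0.49 log units; beyond the scatter), which marks the largest size seen so far. Neither step predicts a direction here, so no shift beyond the scatter is expected, though a modest one in either direction remains possible. The expected change is a 1.2-fold lower number from compound 3 to compound 4 (0.06 log units; within the scatter). For compound 4 the estimated value in this assay is 1700 nM, with an expected range from 600 nM to 4500 nM.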

Compound 4, half-maximal inhibitory concentration: 4240 nM
Beside the measured number, compound 4's estimate is 2.5-fold (0.40 log units) below it, and the stated range covers the measured number.
By their numbers in this assay, from the lowest: compounds 2, 3, 1 and 4 (each within the scatter of the next, the first and the last beyond it).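

Read in this assay the exchange of methoxy for benzyloxy gives a 2.2-fold higher number from compound 3 to compound 4 (0.33 log units; beyond the scatter) and so shows for the first time that this place responds to substitution, with phenyl on a saturated chain carbon bound to an oxygen bringing a modest weakening of inhibition rather than a loss of all measurable activity. The earlier exchange of hydrogen for phenyl, at a different place, gave a 1.8-fold higher number from compound 2 to compound 3 (0.27 log units; within the scatter) and stayed within the scatter, so the same added group does not behave alike at the two places in these compounds. Nothing available here accounts for the rise in the number at this place.

The compounds shown offer a single pair for this change, on the background of compound 3, so it remains open whether phenyl would have the same effect on the background of compound 2 or compound 1. They also leave open what intermediate or different groups on this oxygen would do, such as ethyl, a longer chain, or a chain ending in an amine or a carboxylic acid.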